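Methylation on a Ring Nitrogen Across Two Kinase Cores

The source may report more compounds than this note shows. Statements on the series, on what has been measured and on what is new or still open speak of the compounds shown alone.

Measured so far, in an assay on isolated protein for inhibition of RAC-alpha serine/threonine-protein kinase (Homo sapiens), read by mobility shift assay, tested at 30 uM; a lower number here means less inhibition, a higher number more inhibition at the concentration tested (going by the name of the read-out):
compound 1, `Cc1cc2[nH]nc(N)c2c(=O)[nH]1`, gives -3%;
compound 2, `Cc1cc2[nH]nc(N)c2c(N2CCCCC2)n1`, gives 36%;
compound 3, `Cc1cc2c(c(N)nn2C)c(=O)[nH]1`, gives 11%.

Compound 2 has the highest number of the three, and its steps to compound 3 and compound 1 are both beyond the scatter. The change from compound 1 to compound 3 is methyl in place of hydrogen on an aromatic nitrogen, and it brought a number 14 percentage points higher from compound 1 to compound 3 (beyond the scatter) in this assay.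

Compound 4, `Cc1cc2c(c(N)nn2C)c(N2CCCCC2)n1`, is not yet measured. It differs from compound 2 by methyl in place of hydrogen on an aromatic nitrogen, the same change as from compound 1 to compound 3, at a place described in identical words. The difference between the cores of compound 1 and compound 2 is not broken down here.

Taking the earlier step as a guide, the change from compound 2 to compound 4 in this assay is expected to give a number 14 percentage points higher from compound 2 to compound 4 (beyond the scatter), because compound 3 showed a number 14 percentage points higher from compound 1 to compound 3 (beyond the scatter) over compound 1. Compound 4 is therefore estimated at 50%, likely between 30% and 70%.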

Compound 4, a percentage reported as inhibition, at one concentration (the size of the read-out at that concentration, not a potency): 6%
Beside the measured number, compound 4's estimate is 44 percentage points above it; the measured number lies below the stated range.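

In this assay, methyl in place of hydrogen on the aromatic nitrogen gave a number 30 percentage points lower from compound 2 to compound 4 (beyond the scatter), so the step seen on one core did not carry over to the other, and its direction reversed: the same change on two cores in this assay, a number 14 percentage points higher (beyond the scatter) from compound 1 to compound 3 and a number 30 percentage points lower (beyond the scatter) from compound 2 to compound 4, 44 percentage points apart, beyond the scatter of two such steps For these two pairs, then, a step measured on one core is a poor guide to the same change on the other. This does not show why the two cores respond differently, and two pairs cannot establish a rule for the wider series.

The compounds shown leave open whether an ethyl group or a longer chain on the same nitrogen would follow the methyl steps on either core. They also leave open which part of the difference between the two cores decides the direction of the step.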